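A few compounds are considered here, and "the series" means these few. Any claim that something is new, unique, unknown or untested is made for them only; others in the source may bear on it.

Three compounds share a core built from an azetidine ring linked through an ether oxygen to a pyridine, differing only in the group on the pyridine. In an assay on brain for binding affinity to Neuronal acetylcholine receptor; alpha4/beta2 (Rattus norvegicus), read by radioligand binding (a lower number here means a stronger inhibitor, a higher number a weaker inhibitor), compound 1 `Brc1ccc(OC[C@@H]2CCN2)cn1` gives 0.021 nM, compound 2 `COc1ccc(OC[C@@H]2CCN2)cn1` gives 1.3 nM, and compound 3 `Clc1cncc(OC[C@@H]2CCN2)c1` gives 0.042 nM. Compound 3 therefore holds the second highest of the three numbers: its number and that of compound 1 lie within the usual scatter of each other, so no order between them can be claimed, while compound 2 sits well beyond the scatter with a clearly higher number.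

Among the compounds with values here, only one step between measured compounds is available, and it is large: a 62-fold higher number from compound 1 to compound 2 (1.79 log units; beyond the scatter), a swap of a halogen for methoxy. The step from compound 3 to compound 4 `Cc1cncc(OC[C@@H]2CCN2)c1` is of a different kind: methyl in place of chloro on an aromatic carbon. A halogen again leaves, but what enters is methyl rather than methoxy, and the earlier step gives no direct measure of such a change. The expectation is that compound 4 remains close to compound 3, with at most a modest rise in the number, expressed as a 3.6-fold higher number from compound 3 to compound 4 (0.55 log units; beyond the scatter). Compound 4 is therefore estimated at 0.15 nM, within a range of 0.03 nM to 0.8 nM.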

Compound 4, inhibition constant: 0.047 nM
The estimate for compound 4 lay 3.2-fold (0.50 log units) above the measured number; the range from low to high includes it.
By their numbers in this assay, from the lowest: compounds 1, 3 and 4 (each within the scatter of the next, the first and the last beyond it); then compound 2.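

In this assay, a 1.1-fold higher number from compound 3 to compound 4 (0.05 log units; within the scatter) stays within the scatter, so at this aromatic carbon, two atoms from the ring nitrogen, the compounds shown do not separate methyl from chloro. Within the data shown here, this is the first direct reading of a swap at this place: the only earlier step, a 62-fold higher number from compound 1 to compound 2 (1.79 log units; beyond the scatter), was methoxy in place of bromo, a different change, and its large size does not carry over to the exchange of chloro for methyl. No measurement here bears on why the two groups give such similar numbers.

On these data alone, it remains open whether methoxy at this same place would bring a large step like the earlier one, or whether the number would hold there. As far as these compounds go, it is equally open how an amine, a carboxylic acid or a longer chain such as propyl would read at this carbon, so the tolerance seen for chloro and methyl cannot be extended to groups beyond these two.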